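The source may report more compounds than this note shows. Statements on the series, on what has been measured and on what is new or still open speak of the compounds shown alone.

Among the measured compounds shown here, in an ADME assay (liver) for pharmacokinetics, with Liver microsome (Rattus norvegicus) as the target, read by LC-MS, using microsomes, tested at 2 uM (on this read-out lower numbers stand for slow clearance and higher numbers for fast clearance), only two related compounds have numbers so far. Compound 1 `O=C(N[C@@H]1CCCC[C@H]1O)c1cnc(Oc2ccccc2)c(-c2ccc(Cl)cc2)c1` gives 0.353 mL/min/kg, and compound 2 `C[C@](O)(CNC(=O)c1cnc(OCC2CC2)c(-c2ccc(Cl)cc2)c1)C1CC1` gives 0.0024 mL/min/kg. Compound 2 therefore holds the lower of the two numbers, and its gap to compound 1 lies beyond the scatter of repeat measurements. These two compounds differ in more than one place, so the gap cannot be pinned on any single group.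

Compound 3 `O=C(N[C@H]1CCCC[C@H]1O)c1cnc(OCC2CC2)c(-c2ccc(Cl)cc2)c1` keeps the rest of compound 2 and changes only the group on the amide-type nitrogen: a group of 7 heavy atoms (6 carbon, 1 oxygen; one six-membered non-aromatic ring of carbon only) in place of a group of 7 heavy atoms (6 carbon, 1 oxygen; one three-membered non-aromatic ring of carbon only), on an amide-type nitrogen. The atoms stay the same but are joined differently, with a 2-hydroxycyclohexyl now in that place. For the measured compounds named here, no measured pair isolates this swap. Going by the values given here, the only guide is compound 1, which also carries a 2-hydroxycyclohexyl, in a different stereochemical form, and stands at 0.353 mL/min/kg. A rise beyond the scatter is therefore expected, with an estimated size of a 21-fold higher number from compound 2 to compound 3 (1.32 log units; beyond the scatter). In this assay, compound 3 is estimated at 0.05 mL/min/kg, with an expected range from 0.006 mL/min/kg to 0.4 mL/min/kg.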

Compound 3, clearance: 0.111 mL/min/kg
Beside the measured number, compound 3's estimate is 2.2-fold (0.35 log units) below it, within the range that was stated.
By their numbers in this assay, from the lowest: compound 2; then compound 3; then compound 1.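

In this assay, the group on the amide-type nitrogen matters on its own: with the rest of the molecule held fixed, putting 2-hydroxycyclohexyl in place of the group with the three-membered carbon ring gives a 46-fold higher number from compound 2 to compound 3 (1.67 log units; beyond the scatter), a large step. The two groups have the same counts of heavy atoms, hydrogen-bond donors and hydrogen-bond acceptors, and neither carries a net charge, so a large change in clearance here comes without any change in those counts; what differs is the ring, the way the atoms are joined and the number of defined stereocentres. Nothing measured here explains why the number rises.

The compounds shown do not tell whether the step follows the six-membered ring itself, the placing of the hydroxyl or the stereochemical form, as only this one pair isolates a change at this position. A plain cyclohexyl without the hydroxyl, or a 2-hydroxycyclopentyl, on the same nitrogen and with the rest of compound 3 unchanged, would help separate these possibilities.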